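The compounds below may be only part of what the source reports. "The series", "measured", "known", "first", "only" and "open" are said of these compounds alone.

In an ADME assay on NIH3T3 cells (Mus musculus) for cytotoxicity, read by MTT assay (a lower number here means a stronger inhibitor, a higher number a weaker inhibitor), compound 1 (`N#Cc1c(-c2ccccc2O)c(C#N)c(=O)n(/N=C/c2cn(-c3ccccc3)nc2-c2ccccc2)c1N`) gives 162 ug/mL, compound 2 (`N#Cc1c(-c2ccc(O)cc2)c(C#N)c(=O)n(/N=C/c2cn(-c3ccccc3)nc2-c2ccccc2)c1N`) gives 110 ug/mL and compound 3 (`N#Cc1c(-c2ccc(Cl)cc2)c(C#N)c(=O)n(/N=C/c2cn(-c3ccccc3)nc2-c2ccccc2)c1N`) gives 64 ug/mL. For the measured compounds named here, compound 3 has the lowest of these three numbers, but only one of its two comparisons clears the scatter. One is a 2.5-fold lower number from compound 1 to compound 3 (0.40 log units; beyond the scatter), a modest step, and the other is a 1.7-fold lower number from compound 2 to compound 3 (0.24 log units; within the scatter).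

Compound 4 (`N#Cc1c(-c2ccc(F)cc2)c(C#N)c(=O)n(/N=C/c2cn(-c3ccccc3)nc2-c2ccccc2)c1N`) departs from compound 3 at a single place, with fluoro in place of chloro on an aromatic carbon, para to a large group (fluoro in place of chloro on an aromatic carbon). Going by the values given here, no measured pair exchanges one halogen for another, so the data offer no direct precedent. The closest evidence is the exchange at this same place between compound 2 and compound 3, which was a 1.7-fold lower number from compound 2 to compound 3 (0.24 log units; within the scatter). Moving from the 2-hydroxyphenyl of compound 1 to the 4-hydroxyphenyl of compound 2 was likewise small, at a 1.5-fold lower number from compound 1 to compound 2 (0.17 log units; within the scatter).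

Since even the largest measured step in the set is modest, no change beyond the scatter is expected here, and any direction would be tentative. The expected step is a 1.2-fold higher number from compound 3 to compound 4 (0.07 log units; within the scatter), which stays within the scatter. For compound 4 the estimated value is 75 ug/mL, with an expected range of 42 ug/mL to 135 ug/mL.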

Compound 4, half-maximal inhibitory concentration: > 200 ug/mL
Compound 4: no number, only a limit; the forecaster's own chance of this, stated with the estimate: 3%; middle value at least 2.6-fold (0.42 log units) from the limit.
By their numbers in this assay, from the lowest: compounds 3, 2 and 1 (each within the scatter of the next, the first and the last beyond it). At a limit, above all of these: compound 4.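

In this assay, a single-atom exchange on this aromatic carbon, para to a large group, now shows a step beyond the scatter: fluoro in place of chloro gives an at least 3.1-fold higher number from compound 3 to compound 4 (0.49 log units; beyond the scatter), whereas the earlier exchange at this place, chloro in place of hydroxy, stayed within it at a 1.7-fold lower number from compound 2 to compound 3 (0.24 log units; within the scatter). The result therefore shows that the two halogens at this place are not interchangeable in this assay, although the comparisons with the hydroxyphenyl compounds are less decisive, at an at least 1.8-fold higher number from compound 2 to compound 4 (0.25 log units; that floor lies within the scatter) and an at least 1.2-fold higher number from compound 1 to compound 4 (0.09 log units; that floor lies within the scatter), and these two floors alone do not separate the compounds. Compound 4 carries a limit and not a number, so only the lowest possible size of each of its steps can be read: the limit of > 200 ug/mL in this assay, at which 1 of the 4 values shown sits.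

The compounds shown leave open whether this high reading belongs to fluoro alone or would recur with bromo, methyl or methoxy on the same aromatic carbon. They also leave open how an amine or a carboxylic acid at this place would read, and how far fluoro really stands from chloro once a number replaces the limit.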